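Lengthening the Tail: Benzyl in Place of Phenyl

The compounds below may be only part of what the source reports. "The series", "measured", "known", "first", "only" and "open" are said of these compounds alone.

Compound 1 `C[C@@H](NCc1ccc(OCc2ccccc2)cc1)C(N)=O` gives 23.8 mg/kg in a functional assay on the whole organism with Mus musculus as the target; a higher number here means that more compound is needed for the effect, a lower number that less compound is needed.
Compound 2 `C[C@@H](NCc1ccc(Cc2ccccc2)cc1)C(N)=O` gives 15.7 mg/kg in this assay.
Compound 3 `C[C@@H](NCc1ccc(CCc2ccccc2)cc1)C(N)=O` gives 40.3 mg/kg in this assay.

All three share a core that ends in a ring carrying a side chain, and only that side chain varies. Compound 1 and compound 2 differ in how the side chain is attached to the core; the difference between these two cores is not broken down here, and their numbers in this assay lie within the usual scatter of each other, so no order between them can be claimed.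

Among the compounds with values here, the one step that can be read as a single structural change is benzyl in place of phenyl on a saturated chain carbon bound to an aromatic carbon. It made a 2.6-fold higher number from compound 2 to compound 3 (0.41 log units; beyond the scatter), meaning that more of compound 3 than of compound 2 was needed for the same effect in mice.

Compound 4 `C[C@@H](NCc1ccc(OCCc2ccccc2)cc1)C(N)=O` has not yet been measured. It arises from compound 1 by benzyl in place of phenyl on a saturated chain carbon bound to an oxygen on an aromatic ring. Within the data shown here, this is the same kind of change as the one from compound 2 to compound 3, but not the same: there the chain carbon is bound to an aromatic carbon, here it is bound to an oxygen on an aromatic ring. Resting on the single observed step of a 2.6-fold higher number from compound 2 to compound 3 (0.41 log units; beyond the scatter), compound 4 is expected to need more compound than compound 1, by roughly a 2.1-fold higher number from compound 1 to compound 4 (0.32 log units; beyond the scatter). Among the measured compounds shown here, with only one earlier example, and that at a different place, the expectation is loose. In this assay compound 4 is estimated at 50 mg/kg, with a likely range from 25 mg/kg to 100 mg/kg.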

Compound 4, dose for half-maximal effect: 24.9 mg/kg
Beside the measured number, compound 4's estimate is 2.0-fold (0.30 log units) above it, outside the stated range (below it).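

On the core of compound 1, benzyl in place of phenyl on a saturated chain carbon bound to an oxygen on an aromatic ring gave a 1.0-fold higher number from compound 1 to compound 4 (0.02 log units; within the scatter), so in this assay this change leaves no readable difference between the two compounds, unlike the step beyond the scatter seen on the core of compound 2. Even so, the two steps cannot be told apart, since the gap between them is no larger than two such noisy measurements can produce on their own: the same change on two cores in this assay, a 2.6-fold higher number (0.41 log units; beyond the scatter) from compound 2 to compound 3 and a 1.0-fold higher number (0.02 log units; within the scatter) from compound 1 to compound 4, 2.5-fold (0.39 log units) apart, within the scatter of two such steps This shows that the higher number seen on the core of compound 2 did not clearly reappear on the core of compound 1, but it does not show that the change behaves differently on the two cores, and with a single pair on each core it gives no firm rule for carrying the change over in either direction.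

On these data alone, whether a longer chain at this same place would give a number readably different from that of compound 1 remains open. As far as these compounds go, it is also open whether a carboxylic acid in place of the amide shared by all four compounds would alter the picture in this assay.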